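Oxygen for Sulfur in the Six-Membered Ring

The compounds below may be only part of what the source reports. "The series", "measured", "known", "first", "only" and "open" are said of these compounds alone.

Of the compounds shown here, two have been measured in a functional assay on A-431 cells (Homo sapiens) for cytotoxicity, read by MTT assay, with a stated time of 72 h, tested at 3 uM; a lower number here means less inhibition of growth, a higher number more inhibition of growth at the concentration tested. Compound 1 `N/C(=N\NC(=S)N1CCOCC1)c1ccccn1` gives 43.1%. Compound 2 `Cc1cccc(/C(N)=N/NC(=S)N2CCSCC2)n1` gives 51.7% in this assay. Compound 2 carries the higher of the two numbers, but its gap to compound 1 lies within the scatter of repeated measurements, so the two cannot be told apart. They also differ from each other in two places at once, so no single structural change can be read from this pair.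

The next compound, compound 3 `Cc1cccc(/C(N)=N/NC(=S)N2CCOCC2)n1`, keeps everything in compound 2 except one ring: morpholin-4-yl in place of thiomorpholin-4-yl on a thiocarbonyl carbon. Within the data shown here, no measured pair shows this exchange on its own, so its effect in this assay is unknown. Among the measured compounds shown here, with only two measured numbers, and those within scatter of each other, there is no ground to expect a shift beyond the scatter in either direction. The estimated step of a number 5.7 percentage points lower from compound 2 to compound 3 (within the scatter) therefore amounts to no clear change. The estimate for compound 3 is 46%, with a range from 30% to 62%.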

Compound 3, percent growth inhibition at one concentration: 45.8%
Compound 3: middle estimate off by 0.2 percentage points, on the high side; low and high end bracket the measured number.
By their numbers in this assay, from the lowest: compounds 1, 3 and 2 (each within the scatter of the next).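

The morpholin-4-yl and thiomorpholin-4-yl rings can now be compared on their own: in this assay morpholin-4-yl in place of thiomorpholin-4-yl on a thiocarbonyl carbon gives a number 5.9 percentage points lower from compound 2 to compound 3 (within the scatter) and so leaves the two compounds indistinguishable at this position. Compound 3 also isolates a second change, methyl in place of hydrogen on an aromatic carbon, which gives a number 2.7 percentage points higher from compound 1 to compound 3 (within the scatter) and likewise cannot be told apart from the spread of repeated measurements. Nothing measured beyond these numbers bears on either result.

Going by these compounds, it remains open whether a ring with a second nitrogen, such as piperazin-1-yl, or an open-chain dimethylamino group on the thiocarbonyl carbon would move the growth inhibition beyond the scatter. On these data alone, it is equally open whether ethyl or methoxy in place of methyl on the aromatic carbon would do so, and whether these two exchanges would stay indistinguishable at other concentrations or in other cell lines.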